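Replacing a fluorophenyl arm with a short branched chain

The compounds below may be only part of what the source reports. "The series", "measured", "known", "first", "only" and "open" are said of these compounds alone.

Compound 1, with the structure `O=C(CCCCCCN(Cc1ccc(F)cc1)c1ncc(C(=O)NCCCn2ccnc2)s1)NO`, was tested in a functional assay on HepG2 cells (Homo sapiens) for inhibition, read by MTT assay, with a stated time of 72 h (a higher number here means a weaker inhibitor, a lower number a stronger inhibitor), where compound 1 gives 9400 nM. Compound 2, with the structure `O=C(CCCCCCN(Cc1ccc(F)cc1)c1ncc(C(=O)NCc2cccnc2)s1)NO`, differs from it only on a saturated chain carbon bound to an amide-type nitrogen, where pyridin-3-yl replaces 2-(1H-imidazol-1-yl)ethyl; in this assay compound 2 gives 14000 nM. That change produced a 1.5-fold higher number from compound 1 to compound 2 (0.17 log units; within the scatter), so the two numbers cannot be told apart, and compound 1 simply has the lower of the two numbers seen so far.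

Compound 3, with the structure `CC(C)CCN(CCCCCCC(=O)NO)c1ncc(C(=O)NCCCn2ccnc2)s1`, departs from compound 1 at a different place, on a saturated chain carbon bound to a nitrogen on an aromatic ring: isobutyl in place of 4-fluorophenyl on a saturated chain carbon bound to a nitrogen on an aromatic ring. Among the compounds with values here, no measured pair touches this part of the molecule, so the single known step gives no direct guide. With the rest of the structure unchanged, the expectation is a step of a 1.3-fold higher number from compound 1 to compound 3 (0.11 log units; within the scatter), that is, no difference beyond the scatter. Compound 3 is therefore estimated at 12000 nM in this assay, with a range from 5000 nM to 30000 nM.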

Compound 3, half-maximal inhibitory concentration: 24000 nM
For compound 3 the middle estimate is 2.0-fold (0.30 log units) below the measured one; the measured number falls inside the stated range.
By their numbers in this assay, from the lowest: compounds 1, 2 and 3 (each within the scatter of the next, the first and the last beyond it).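

Unlike the earlier change, pyridin-3-yl in place of 2-(1H-imidazol-1-yl)ethyl, which stayed within the scatter, putting isobutyl in place of 4-fluorophenyl on a saturated chain carbon bound to a nitrogen on an aromatic ring gives a 2.6-fold higher number from compound 1 to compound 3 (0.41 log units; beyond the scatter) in this assay and so produces the first readable difference among these compounds. Here the group that leaves has 7 heavy atoms, including a six-membered aromatic ring and a fluorine, while the group that enters has 4 carbon atoms and no ring, and the compound with the ring has the lower number, although this rests on a single modest step. Nothing available explains why the number rises with this swap.

The compounds shown do not separate the role of the ring from that of the fluorine, and a plain benzyl or a cyclohexylmethyl group in place of the 4-fluorobenzyl would be needed to tell those parts apart. From the compounds shown here alone, it also remains open whether the same swap gives a similar step when the pyridin-3-yl arm of compound 2 is present instead of the imidazole-bearing arm.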